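The compounds below may be only part of what the source reports. "The series", "measured", "known", "first", "only" and "open" are said of these compounds alone.

Series notes, tetrabromobenzotriazoles with a hydroxylated side chain on the ring nitrogen, all tested in a functional assay on MCF7 cells (Homo sapiens) for antiproliferative activity, read by MTT assay, with a stated time of 48 h, tested at 100 uM; on this read-out lower numbers stand for a stronger effect and higher numbers for a weaker effect at the one concentration tested.

Compound 1 `OCC(O)Cn1nc2c(Br)c(Br)c(Br)c(Br)c2n1` gives 8%. Compound 3 `C[C@@H](O)CCn1nc2c(Br)c(Br)c(Br)c(Br)c2n1` gives 0%; the step of a number 8 percentage points lower from compound 1 to compound 3 (within the scatter) is the only one measured with a single change, and it lies within the scatter. Compound 2 `OC(CCn1nc2c(Br)c(Br)c(Br)c(Br)c2n1)c1ccccc1` gives 0%, level with compound 3 at the digits shown; compound 1 differs from it only within the scatter, so no ordering among the three is supported.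

Compound 4 `OC(CCn1nc2c(Br)c(Br)c(Br)c(Br)c2n1)c1cccc(Br)c1` differs from compound 2 by bromo in place of hydrogen on an aromatic carbon. Among the compounds with values here, no measured step touches the aromatic ring of the side chain, so nothing in hand bears directly on this change; the one step measured, in the hydroxylated chain, was itself within the scatter, and all three measured values sit close together near the floor of the read-out. For compound 4 in this assay no movement beyond the scatter is expected, a number 3 percentage points higher from compound 2 to compound 4 (within the scatter). The estimate for compound 4 is 3%, with a range from 0% to 14%.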

Compound 4, a percentage reported as activity, at one concentration (the size of the read-out at that concentration, not a potency): 0%
The estimate for compound 4 lay 3 percentage points above the measured number; low and high end bracket the measured number.
By their numbers in this assay, from the lowest: compounds 2, 3, 4 and 1 (each within the scatter of the next).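

In this assay, within the data shown here, phenyl to 3-bromophenyl gives no change at the digits printed from compound 2 to compound 4 (within the scatter), the first reading on the aromatic ring of the side chain. Bromo on this aromatic carbon therefore leaves the read-out where compound 2 has it, so this ring accepts the added heavy atom without a loss of effect at the one concentration tested. With compound 2 already at the low end of the read-out, any further gain from this change could not be seen, and no measurement on hand speaks to the reason for the result.

From the compounds shown here alone, whether an amine or a carboxylic acid in place of the bromo, or a longer chain between the hydroxyl-bearing carbon and the ring nitrogen, would move the number stays open. With a single concentration near the floor, the potency of compound 2 and compound 4 also remains unresolved.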